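This account rests on a few compounds, and the source may have more. Where it says the series, first, only, none or still open, it means among the compounds named here.

Compound 1 `Cc1ccc(-c2cnc(Nc3ccc(C#N)cc3)nc2Oc2c(C)cc(C#N)cc2C)cc1`: 26100 nM
Compound 2 `Cc1cc(C#N)cc(C)c1Oc1nc(Nc2ccc(C#N)cc2)ncc1-c1ccc(Cl)cc1`: 72600 nM

In an ADME assay on MT4 cells (Homo sapiens) for cytotoxicity, read by MTT assay, with a stated time of 5 days (on this read-out higher numbers stand for lower toxicity in this test and lower numbers for higher toxicity in this test), compound 2 holds the higher of the two numbers shown; the one measured step between them is a 2.8-fold higher number from compound 1 to compound 2 (0.44 log units; beyond the scatter), a modest change at the same attachment point. Compound 3 `Cc1cc(C#N)cc(C)c1Oc1nc(Nc2ccc(C#N)cc2)ncc1-c1cccc2ccccc12` carries a different change there: naphthalen-1-yl in place of 4-chlorophenyl on an aromatic carbon. Among the compounds with values here, no measured step exchanges a single aromatic ring for a fused pair, so the measured step gives only a rough sense of how much this position can move the number. Compound 3 is therefore expected to stay near compound 2, within or just beyond the scatter, in no clear direction. For compound 3 the expected value is 50000 nM, with a range from 15000 nM to 150000 nM. That expectation means a 1.5-fold lower number from compound 2 to compound 3 (0.16 log units; within the scatter).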

Compound 3, half-maximal cytotoxic concentration: > 267000 nM
Compound 3: only a limit was reported; the forecaster's own chance of this, stated with the estimate: 25%; at least 5.3-fold (0.72 log units) between middle value and limit.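

Naphthalen-1-yl in place of 4-chlorophenyl gives an at least 3.6-fold higher number from compound 2 to compound 3 (0.56 log units; beyond the scatter), and in place of 4-methylphenyl it gives an at least 10-fold higher number from compound 1 to compound 3 (1.00 log units; beyond the scatter). So in this assay, a second fused aromatic ring at this position goes with lower toxicity in this test, not higher. For compound 3 the reported figure is a limit, not a number: the limit of > 267000 nM in this assay, at which 1 of the 3 values shown sits.

All three compounds carry aromatic carbon rings at this position. From the compounds shown here alone, how a pyridyl ring, or a phenyl ring bearing an amine or a carboxylic acid, would read here remains open.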